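Trifluoromethyl on compound 3: a flat series so far

The source may hold more compounds than are shown below. What is called first, only, known or untested is meant among the compounds shown, and "the series" means these compounds.

In an ADME assay on HeLa cells (Homo sapiens) for cytotoxicity, read by MTT assay, with a stated time of 72 h (a lower number here means that less compound is tolerated, a higher number that more compound is tolerated), compound 1 `Fc1ccccc1/C=N/c1sc2c(c1-c1nc3ccccc3s1)CCC2` gives 355 ug/mL and compound 2 `Clc1ccc(/C=N/c2sc3c(c2-c2nc4ccccc4s2)CCC3)c(Cl)c1` gives 345 ug/mL while compound 3 `C(=N/c1sc2c(c1-c1nc3ccccc3s1)CCCC2)\c1ccccc1` gives 333 ug/mL on a different core. Compound 3 thus stands level with the other two, as all three values lie within the scatter of each other.

The next compound is compound 4 `FC(F)(F)c1ccc(/C=N/c2sc3c(c2-c2nc4ccccc4s2)CCCC3)cc1`. The change is phenyl to 4-(trifluoromethyl)phenyl trifluoromethyl in place of hydrogen on an aromatic carbon with the new group para to a large group.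

Going by the values given here, only one measured step bears on this change, namely a 1.0-fold lower number from compound 1 to compound 2 (0.01 log units; within the scatter) and it stays within the scatter. Among the compounds with values here, that step also alters the substituents on an aromatic ring, but it does so on the core of compound 1, and no measured compound carries trifluoromethyl. The support is therefore indirect, and the data do not show how this group behaves on the core of compound 3.

No step beyond the scatter is expected in this assay and the estimated move is a 1.0-fold higher number from compound 3 to compound 4 (0.00 log units; within the scatter) with no firm direction expected. For compound 4 the expected value is 335 ug/mL within an estimated range (230 ug/mL to 470 ug/mL).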

Compound 4, half-maximal cytotoxic concentration: 369 ug/mL
Compound 4: the middle estimate sits 1.1-fold (0.04 log units) below what was measured; measured number inside the range.
By their numbers in this assay, from the lowest: compounds 3, 2, 1 and 4 (each within the scatter of the next).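

In this assay the change to 4-(trifluoromethyl)phenyl, on an aromatic carbon para to a large group, gives a 1.1-fold higher number from compound 3 to compound 4 (0.04 log units; within the scatter) and so stays within the scatter. Going by these compounds alone, this is the first direct reading of trifluoromethyl on the core of compound 3; the earlier support was only the exchange of 2-fluorophenyl for 2,4-dichlorophenyl on the core of compound 1, which gave a 1.0-fold lower number from compound 1 to compound 2 (0.01 log units; within the scatter) as its one step. Both measured steps now lie within the scatter, none of the four compounds goes against this flat picture, and no measured information is available to explain it.

Going by these compounds, how trifluoromethyl behaves on the core of compound 1 remains open, as the present reading comes from the core of compound 3 alone. Also open, on these data alone, is whether an amine, a carboxylic acid or a longer chain at this same place on the ring would leave the number within the scatter as trifluoromethyl does.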